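Ethoxy in place of fluoro: notes toward compound 4

This account rests on a few compounds, and the source may have more. Where it says the series, first, only, none or still open, it means among the compounds named here.

The series is followed in a functional assay on A-375 cells (Homo sapiens) for antiproliferative activity, read by MTT assay, with a stated time of 24 h, tested at 33.33 ug/mL; a higher number here means a stronger effect of the compound at the concentration tested, a lower number a weaker effect. Compound 1 `CCOc1ccc2nc(C(=O)Nc3c(F)cc(-c4cccc(F)c4)cc3F)c(C)c(O)c2c1` gives 16.3%. Compound 2 `CCc1ccc2nc(C(=O)Nc3c(F)cc(-c4cccc(F)c4)cc3F)c(C)c(C(=O)O)c2c1` gives 47.1%. Compound 3 `Cc1c(C(=O)Nc2c(F)cc(-c3cccc(F)c3)cc2F)nc2ccc(F)cc2c1C(=O)O` gives 41.3%, which is the second highest of the three numbers; its nearest neighbour is compound 2, and the gap between them, a number 5.8 percentage points lower from compound 2 to compound 3 (within the scatter), is within the scatter, while compound 1 sits far below it, beyond the scatter.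

Compound 4 `CCOc1ccc2nc(C(=O)Nc3c(F)cc(-c4cccc(F)c4)cc3F)c(C)c(C(=O)O)c2c1` is not yet measured. Its difference from compound 3 is ethoxy in place of fluoro on an aromatic carbon.

Going by the values given here, only one measured step touches that same aromatic carbon, the change from ethyl to fluoro, a number 5.8 percentage points lower from compound 2 to compound 3 (within the scatter), which did not move the read-out beyond the scatter. Among the compounds with values here, compound 1 also carries ethoxy at that carbon, but it differs from compound 4 elsewhere as well, and no single step connects the two, so its low value cannot be read as the effect of ethoxy alone. Within the data shown here, on the one comparable step, exchanging fluoro for ethoxy is expected to give little or no change beyond the scatter, so the expected step of a number 2.7 percentage points higher from compound 3 to compound 4 (within the scatter) is small.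

Compound 4 is therefore estimated at 44%, in the range 28% to 60%.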

Compound 4, a percentage reported as inhibition, at one concentration (the size of the read-out at that concentration, not a potency): 51.2%
Compound 4: middle estimate off by 7.2 percentage points, on the low side; the range from low to high includes it.
By their numbers in this assay, from the lowest: compound 1; then compounds 3, 2 and 4 (each within the scatter of the next).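

In this assay, ethoxy on this aromatic carbon can now be read directly against two other groups. Ethoxy in place of fluoro gives one step (a number 9.9 percentage points higher from compound 3 to compound 4 (within the scatter)) and ethoxy in place of ethyl gives another (a number 4.1 percentage points higher from compound 2 to compound 4 (within the scatter)), so the read-out does not separate fluoro, ethyl and ethoxy here, and this carbon accepts the larger ethoxy group without a change beyond the scatter. Going by these compounds alone, with ethoxy held constant, the one large step lies at a different aromatic carbon, where carboxy stands in place of hydroxy (a number 34.9 percentage points higher from compound 1 to compound 4 (beyond the scatter)), which ties the low value of compound 1 to hydroxy rather than to ethoxy. Nothing available gives a reason for either finding.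

From the compounds shown here alone, whether the read-out stays unchanged at the ethoxy-bearing carbon with an amine or a longer chain such as butoxy remains open. Going by these compounds, at the other carbon, only hydroxy and carboxy can be compared, so it is also open how a primary amide or a methyl ester there would compare with the carboxylic acid.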